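Amide Substituent Change in a Series Limited by Cytotoxicity

The compounds below may be only part of what the source reports. "The series", "measured", "known", "first", "only" and "open" are said of these compounds alone.

Compound 1 `CCOC(=O)/C=C/c1cnc(Nc2ccc(C#N)cc2)nc1Oc1c(C)cc(C#N)cc1C`, compound 2 `C#CCNC(=O)/C=C/c1cnc(Nc2ccc(C#N)cc2)nc1Oc1c(C)cc(C#N)cc1C` and compound 3 `COCCNC(=O)/C=C/c1cnc(Nc2ccc(C#N)cc2)nc1Oc1c(C)cc(C#N)cc1C` share one core and differ only in the group on the carbonyl carbon. In an ADME assay on TZM cells (Homo sapiens) for cytotoxicity, with a stated time of 1 days (a higher number here means that more compound is tolerated, a lower number that less compound is tolerated), compound 1 gives > 227 nM, which is a limit of the assay. Compound 2 gives > 222 nM in this assay, again a limit. Compound 3 gives > 213 nM in this assay, also a limit, so compound 3 stands at a limit like the two others. The steps a step that the two limits leave unreadable from compound 1 to compound 2, a step that the two limits leave unreadable from compound 1 to compound 3 and a step that the two limits leave unreadable from compound 2 to compound 3 have no readable size. Compound 4 `Cc1cc(C#N)cc(C)c1Oc1nc(Nc2ccc(C#N)cc2)ncc1/C=C/C(=O)NC1CCN(S(C)(=O)=O)CC1` differs from compound 3 by 1-(methylsulfonyl)piperidin-4-yl in place of 2-methoxyethyl on an amide-type nitrogen. For the measured compounds named here, since no measured step gives a readable size, no step beyond the scatter is expected in this assay, and the step that the limit leaves unreadable from compound 3 to compound 4 is the expectation. Compound 4 is estimated at 300 nM, between 150 nM and 1000 nM.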

Compound 4, half-maximal cytotoxic concentration: > 175 nM
Compound 4 ended at the assay's limit (the forecaster's own chance of this, stated with the estimate: 80%); the middle value is on the limit's open side.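

For the compounds shown here, compound 1, compound 2, compound 3 and compound 4 all stand at limits in this assay, so no step among them can be read. The compounds shown leave open whether the group on the carbonyl carbon changes cytotoxicity at all.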